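Swapping a benzyl halide on a shared triazole arm

The source may report more compounds than this note shows. Statements on the series, on what has been measured and on what is new or still open speak of the compounds shown alone.

Compound 1 `COc1ccc(/C=C2\CN(C(=S)SCc3cn(Cc4ccc(F)cc4)nn3)C/C(=C\c3ccc(OC)cc3)C2=O)cc1`: > 100000 nM
Compound 2 `COc1ccc(/C=C2\CN(C(=S)SCc3cn(Cc4cccc(Cl)c4)nn3)C/C(=C\c3ccc(OC)cc3)C2=O)cc1`: 32000 nM
Compound 3 `O=C1/C(=C/c2ccccc2F)CN(C(=S)SCc2cn(Cc3ccc(F)cc3)nn2)C/C1=C\c1ccccc1F`: 56900 nM

Of the compounds shown here, three have been tested in a functional assay on MCF7 cells (Homo sapiens) for cytotoxicity, read by MTT assay, with a stated time of 24 h; a higher number here means a weaker inhibitor, a lower number a stronger inhibitor. For compound 1 the result is a limit of the assay rather than a number, namely > 100000 nM (the limit of > 100000 nM in this assay, at which 1 of the 3 values shown sits). Compound 2 gives 32000 nM in this assay, and compound 3 gives 56900 nM. The values of compound 2 and compound 3 lie within the usual scatter of each other, so no order between them can be read.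

The change from compound 1 to compound 2 is 3-chlorophenyl in place of 4-fluorophenyl on a saturated chain carbon bound to an aromatic nitrogen, and it made a step of an at least 3.1-fold lower number from compound 1 to compound 2 (0.49 log units; beyond the scatter) in this assay.

Compound 3 carries a different core from compound 1; how the two cores differ is not broken down here. Compound 4 `O=C1/C(=C/c2ccccc2F)CN(C(=S)SCc2cn(Cc3cccc(Cl)c3)nn2)C/C1=C\c1ccccc1F` has the core of compound 3 and carries the same change as the one already measured: 3-chlorophenyl in place of 4-fluorophenyl on a saturated chain carbon bound to an aromatic nitrogen. Because this change gave an at least 3.1-fold lower number from compound 1 to compound 2 (0.49 log units; beyond the scatter), a step in the same direction is expected on the other core as well, though a single measured example is a thin basis, and the starting point in compound 1 was itself only a limit. For compound 4 the expected step from compound 3 is a 3.2-fold lower number from compound 3 to compound 4 (0.50 log units; beyond the scatter) in this assay. Compound 4 is therefore estimated at 18000 nM, with a range from 6000 nM to 60000 nM.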

Compound 4, half-maximal inhibitory concentration: > 100000 nM
Compound 4: no number, only a limit; the forecaster's own chance of this, stated with the estimate: 5%; at least 5.5-fold (0.74 log units) between middle value and limit.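

On the core of compound 3, the swap from 4-fluorobenzyl to 3-chlorobenzyl gave a step of an at least 1.7-fold higher number from compound 3 to compound 4 (0.24 log units; that floor lies within the scatter) in this assay, and the result for compound 4 is a limit of the assay rather than a number. Set beside the earlier step, the same change does not carry over from one core to the other with the same outcome: the same change on two cores in this assay, an at least 3.1-fold lower number (0.49 log units; beyond the scatter) from compound 1 to compound 2 and an at least 1.7-fold higher number (0.24 log units; that floor lies within the scatter) from compound 3 to compound 4, at least 5.4-fold (0.73 log units) apart, beyond the scatter of two such steps This shows that, in these two pairs, the result of the swap depends on the core it sits on, but it does not show the true size of either step or which difference between the cores matters, and two pairs are too few to give a rule for the series, since compound 1 and compound 4 both stand at the limit: the limit of > 100000 nM in this assay, at which 2 of the 4 values shown sit.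

The compounds shown leave open what happens to this swap on a third core, which would show whether either of the two outcomes is the more usual one. They also leave open how a plain benzyl group, or a benzyl group carrying an amine or a carboxylic acid, would compare with the two halogen-bearing arms on each core.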